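Swapping a Nitrobenzoic Acid for a Benzimidazole

A few compounds are considered here, and "the series" means these few. Any claim that something is new, unique, unknown or untested is made for them only; others in the source may bear on it.

Measured so far:
- compound 1, `O=C(O)c1ccc(CN2CCC[C@H](O[C@H](CO)c3cc(Cl)cc(Cl)c3)[C@@H]2c2ccccc2)c([N+](=O)[O-])c1`: 13000 nM
- compound 2, `Cc1cc(C(=O)O)ccc1CN1CC[C@H](OC(CO)c2cc(Cl)cc(Cl)c2)[C@@H]1c1ccccc1`: 185000 nM
- compound 3, `Cc1cc(C(=O)O)ccc1CN1CCC[C@H](O[C@H](CO)c2cc(Cl)cc(Cl)c2)[C@@H]1C1CCCCC1`: > 200000 nM

Of the compounds shown here, three have been tested in an assay on isolated protein for activation of cGMP-dependent protein kinase 1 (Homo sapiens), read by ADP-Glo, with stated times of 30 min and 2 h; on this read-out higher numbers stand for an effect only at larger amounts of compound and lower numbers for an effect already at smaller amounts. Compound 1 gives 13000 nM, the lowest of the two numbers obtained. Compound 2 gives 185000 nM, a higher number that lies beyond the usual scatter of this kind of measurement. Compound 3 returns no number at all, only (the limit of > 200000 nM in this assay, at which 1 of the 3 values shown sits), so it can only be said that its effect, if any, was not seen within the amounts tested. For the measured compounds named here, compounds 2 and 3 differ from compound 1 in more than one place, so no single structural step between measured compounds can be read off.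

The next compound to be measured is compound 4, `OC[C@@H](O[C@H]1CCCN(Cc2nc3ccccc3[nH]2)[C@H]1c1ccccc1)c1cc(Cl)cc(Cl)c1`. It keeps the core of compound 1 and changes one group: 1H-benzimidazol-2-yl in place of 4-carboxy-2-nitrophenyl on a saturated chain carbon bound to an amine nitrogen in a ring. Going by the values given here, no measured pair shows this change, so the expectation rests on the numbers above alone. A move toward larger amounts of compound is expected, a 3.1-fold higher number from compound 1 to compound 4 (0.49 log units; beyond the scatter), since the measured variations on compound 1 have so far given higher numbers or a limit. Compound 4 is therefore estimated at 40000 nM, within a range of 8000 nM to 200000 nM.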

Compound 4, half-maximal effective concentration: > 200000 nM
Compound 4: only a limit was reported (the forecaster's own chance of this, stated with the estimate: 25%); middle value at least 5.0-fold (0.69 log units) away from the limit.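

In this assay, putting 1H-benzimidazol-2-yl in place of 4-carboxy-2-nitrophenyl on a saturated chain carbon bound to an amine nitrogen in a ring gives an at least 15-fold higher number from compound 1 to compound 4 (1.18 log units; beyond the scatter), a large step beyond the scatter. For the compounds shown here, compound 2 and compound 3 each differ from compound 1 in more than one place, so this is the first comparison to show that the group at this place alone can decide whether an effect is read at all, with the rest of the core of compound 1 left unchanged. Compound 4 is reported only as a limit and not as a number, so the true size of the step remains unknown: the limit of > 200000 nM in this assay, at which 2 of the 4 values shown sit.

The change replaces a whole group at once, so the compounds shown do not tell whether the carboxylic acid, the nitro group or the six-membered aromatic ring carrying them accounts for the step. A plain benzyl group at this place, or a 1H-benzimidazol-2-yl group carrying a carboxylic acid, would help separate these parts, and neither is among the compounds shown.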